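Thiazole in Place of Chloromethoxyphenyl on the Amide Carbonyl

This account rests on a few compounds, and the source may have more. Where it says the series, first, only, none or still open, it means among the compounds named here.

Measured compounds in a functional assay on the whole organism (blood) with Rattus norvegicus as the target, with stated times of 24 h and 1 h, at a dose of 5 mg/kg by the intraperitoneal route; a higher number here means a stronger effect of the compound at the dose given, a lower number a weaker effect:
compound 1, `COc1ccc(Cl)cc1C(=O)NCCC1CCN(S(=O)(=O)NC(=O)NC[C@@H]2C[C@@H]3C=C[C@@H]2C3)CC1`, 37%
compound 2, `COc1ccc(NC(=O)NS(=O)(=O)N2CCC(CCNC(=O)c3cc(Cl)ccc3OC)CC2)cc1`, 27%
compound 3, `COc1ccc(Cl)cc1C(=O)NCCC1CCN(S(=O)(=O)NC(=O)NC[C@@H]2C[C@@H]3CC[C@@H]2O3)CC1`, 30%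

Compound 1 stands highest of the three numbers, yet both a number 7 percentage points lower from compound 1 to compound 3 (within the scatter) and a number 10 percentage points lower from compound 1 to compound 2 (within the scatter) lie within the usual scatter, so no order among the three can be claimed. Compound 4, `Cc1ncsc1C(=O)NCCC1CCN(S(=O)(=O)NC(=O)NC[C@@H]2C[C@@H]3C=C[C@@H]2C3)CC1`, differs from compound 1 by 4-methyl-1,3-thiazol-5-yl in place of 5-chloro-2-methoxyphenyl on a carbonyl carbon. Among the measured compounds shown here, every measured step, including a number 3 percentage points higher from compound 2 to compound 3 (within the scatter), changes the group on the urea side of the shared core; none touches the carbonyl carbon where compound 4 differs, so no measured step bears on this change. With nothing to anchor a direction, compound 4 is expected to give 32%, in the range 12% to 52%. The expected step of a number 5 percentage points lower from compound 1 to compound 4 (within the scatter) is estimated to stay within the scatter.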

Compound 4, a percentage reported as activity, at one dose (the size of the read-out at that dose, not a potency): 11%
Compound 4: the middle estimate sits 21 percentage points above what was measured, and the stated range ends above it.
By their numbers in this assay, from the lowest: compound 4; then compounds 2, 3 and 1 (each within the scatter of the next).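

In this assay, among the compounds shown here, the group on the carbonyl carbon proves to matter: 4-methyl-1,3-thiazol-5-yl in place of 5-chloro-2-methoxyphenyl gives a number 26 percentage points lower from compound 1 to compound 4 (beyond the scatter) and is the only step here printed as beyond the scatter, whereas the changes on the urea side all stayed within it. Nothing measured here explains this step. On these data alone, whether a plain phenyl or a pyridine ring on that carbonyl carbon would stay close to compound 1 or fall toward compound 4 remains open, as does whether the same replacement would give a step of similar size with the urea-side groups of compound 2 or compound 3.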